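The source may hold more compounds than are shown below. What is called first, only, known or untested is meant among the compounds shown, and "the series" means these compounds.

In an in vivo ADME assay on the whole organism (plasma, strain Sprague-Dawley) for pharmacokinetics, with Rattus norvegicus as the target (on this read-out higher numbers stand for fast clearance and lower numbers for slow clearance), compound 2 (`Cc1cc(C(C)CC(=O)O)ccc1-c1noc(-c2ccc(OC(C)C)c(C(F)(F)F)c2)n1`) gives 2.9 mL/min/kg and stands level with compound 1 (`Cc1cc([C@@H]2C[C@H]2C(=O)O)ccc1-c1noc(-c2ccc(OC(C)C)c(C(F)(F)F)c2)n1`) at 2.4 mL/min/kg within the usual scatter. Compound 3 (`Cc1cc(CC(C)C(=O)O)ccc1-c1noc(-c2ccc(OC(C)C)c(C(F)(F)F)c2)n1`) has the same atoms as compound 2, joined differently, with 2-carboxypropyl in place of 1-(carboxymethyl)ethyl (2-carboxypropyl in place of 1-(carboxymethyl)ethyl on an aromatic carbon) on an aromatic carbon meta to a methyl group and para to a large group. Within the data shown here, one measured step bears on this change: a 1.2-fold higher number from compound 1 to compound 2 (0.08 log units; within the scatter) lies within the scatter. Among the measured compounds shown here, it swaps a different pair of groups, and no measured compound carries 2-carboxypropyl, so the evidence is thin. No change beyond the scatter is therefore expected in this assay, and neither direction is favoured. The expected size is a 1.0-fold higher number from compound 2 to compound 3 (0.01 log units; within the scatter), well inside the scatter. For compound 3 the estimated value is 3 mL/min/kg, with an expected range from 1.3 mL/min/kg to 7 mL/min/kg.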

Compound 3, clearance: 7 mL/min/kg
Estimate against measurement, compound 3: 2.3-fold (0.37 log units) below; the range from low to high includes it.
By their numbers in this assay, from the lowest: compounds 1 and 2 (each within the scatter of the next); then compound 3.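

In this assay, 2-carboxypropyl in place of 1-(carboxymethyl)ethyl on this aromatic carbon gives a 2.4-fold higher number from compound 2 to compound 3 (0.38 log units; beyond the scatter), so the way the same atoms are joined in this side chain can shift the number beyond the scatter, which the earlier pair did not show. 2-carboxypropyl in place of 2-carboxycyclopropyl gives a 2.9-fold higher number from compound 1 to compound 3 (0.46 log units; beyond the scatter), so 2-carboxypropyl stands apart from both other groups, which remain level with each other within the scatter. No measurement shown accounts for this difference.

Going by these compounds, whether the higher number follows from the position of the methyl branch on the chain remains open, and an unbranched 2-carboxyethyl or a longer 3-carboxypropyl chain would test this. Also open, on these data alone, is whether the step would persist with a primary amide in place of the carboxylic acid.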